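Swapping Methyl for Chloro: What to Expect of Compound 4

The source may hold more compounds than are shown below. What is called first, only, known or untested is meant among the compounds shown, and "the series" means these compounds.

Compound 1, `Cc1ccc(/C=C/C(=O)Nc2nnc(-c3ccc(Cl)cc3)s2)cc1`: in a functional assay on A549 cells (Homo sapiens) for antiproliferative activity, read by MTT assay, with a stated time of 48 h (a higher number here means a weaker inhibitor, a lower number a stronger inhibitor), compound 1 gives 1.25 ug/mL.
Compound 2, `Cc1ccc(/C=C/C(=O)Nc2nnc(-c3ccc(C)cc3)s2)cc1`: in this assay compound 2 gives 1.08 ug/mL.
Compound 3, `Cc1ccc(-c2nnc(NC(=O)/C=C/c3ccc(F)cc3)s2)cc1`: in this assay compound 3 gives 1.23 ug/mL.

All three measured values sit close together, and no ordering among them can be claimed. Compound 4, `O=C(/C=C/c1ccc(F)cc1)Nc1nnc(-c2ccc(Cl)cc2)s1`, has not yet been measured. It differs from compound 3 by one change, (chloro in place of methyl on an aromatic carbon). The same change, with the same surroundings at its place, separates the measured compounds 2 and 1, (chloro in place of methyl on an aromatic carbon), and there it gave a step of a 1.2-fold higher number from compound 2 to compound 1 (0.06 log units; within the scatter), a shift too small to count. The cores of compounds 2 and 3 themselves differ by fluoro in place of methyl on an aromatic carbon, which also left the number essentially unchanged.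

Because the earlier instance of this change produced only a 1.2-fold higher number from compound 2 to compound 1 (0.06 log units; within the scatter), the step from compound 3 to compound 4 in this assay is expected to be similarly small, about a 1.1-fold higher number from compound 3 to compound 4 (0.02 log units; within the scatter). Compound 4 is therefore estimated to give roughly 1.3 ug/mL in this assay, most likely between 0.8 ug/mL and 2.2 ug/mL.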

Compound 4, half-maximal inhibitory concentration: 2.06 ug/mL
For compound 4 the middle estimate is 1.6-fold (0.20 log units) below the measured one; the range from low to high includes it.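

Swapping methyl for chloro gives a 1.7-fold higher number from compound 3 to compound 4 (0.22 log units; within the scatter) in this assay, and this cannot be told apart from the earlier instance of the same swap: the same change on two cores in this assay, a 1.2-fold higher number (0.06 log units; within the scatter) from compound 2 to compound 1 and a 1.7-fold higher number (0.22 log units; within the scatter) from compound 3 to compound 4, 1.4-fold (0.16 log units) apart, within the scatter of two such steps
Swapping methyl for fluoro gives a 1.6-fold higher number from compound 1 to compound 4 (0.22 log units; within the scatter), and this too matches its earlier instance: the same change on two cores in this assay, a 1.1-fold higher number (0.06 log units; within the scatter) from compound 2 to compound 3 and a 1.6-fold higher number (0.22 log units; within the scatter) from compound 1 to compound 4, 1.4-fold (0.16 log units) apart, within the scatter of two such steps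
So on these two cores, each swap behaves the same within the noise of the measurement, and each leaves the number essentially where it was; this does not show that either swap truly raises the number, nor that the steps would stay this small on a third core.

The compounds shown carry only methyl, chloro and fluoro at these places, so it stays open what an amine, a carboxylic acid or a longer chain such as butyl would do there. With only four compounds, each swap has just two instances to compare, and further pairs would be needed before calling either one reliably transferable across this series.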